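Replacing 1H-imidazol-1-yl in compound 2

The source may hold more compounds than are shown below. What is called first, only, known or untested is meant among the compounds shown, and "the series" means these compounds.

Values in a functional assay on RKO cells (Homo sapiens) for antiproliferative activity, read by MTT assay, with a stated time of 5 days; on this read-out higher numbers stand for weaker inhibition and lower numbers for stronger inhibition:
- compound 1 `COc1cc[nH]c1/C=C1\C(=O)Nc2ccc([N+](=O)[O-])c(N3CC[C@@H](O)C3)c21`: 32 nM
- compound 2 `COc1cc[nH]c1/C=C1\C(=O)Nc2ccc([N+](=O)[O-])c(-n3ccnc3)c21`: 3920 nM
- compound 3 `COc1cc[nH]c1/C=C1\C(=O)Nc2ccc([N+](=O)[O-])c(N[C@H]3CC[C@H](N)C3)c21`: not yet measured

Compound 2, at 3920 nM, holds the higher of the two numbers. Compound 3 carries (3-aminocyclopentyl)amino in place of 1H-imidazol-1-yl on an aromatic carbon. Going by the values given here, only one measured step bears on this: a 120-fold higher number from compound 1 to compound 2 (2.09 log units; beyond the scatter), a large step beyond the scatter, with 1H-imidazol-1-yl in place of 3-hydroxypyrrolidin-1-yl. Compound 3 also gives up 1H-imidazol-1-yl for a non-aromatic ring, so a large step to a lower number is expected in this assay. The expected change is an 87-fold lower number from compound 2 to compound 3 (1.94 log units; beyond the scatter). Compound 3 is estimated at 45 nM, within an expected range of 9 nM to 250 nM.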

Compound 3, half-maximal inhibitory concentration: < 15 nM
Compound 3 was reported as a limit; the forecaster's own chance of this, stated with the estimate: 2%; middle value at least 3.0-fold (0.47 log units) from the limit.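

At this position, on an aromatic carbon ortho to a nitro group, the loss seen with 1H-imidazol-1-yl is more than reversed by (3-aminocyclopentyl)amino, with an at least 260-fold lower number from compound 2 to compound 3 (2.41 log units; beyond the scatter). The same group also goes beyond 3-hydroxypyrrolidin-1-yl, with an at least 2.1-fold lower number from compound 1 to compound 3 (0.32 log units; beyond the scatter), so the earlier best number did not mark the end of what this position allows. In this assay, compound 3 is reported only as a limit and not as a number: the limit of < 15 nM in this assay, at which 1 of the 3 values shown sits.

The compounds shown do not tell whether the primary amine on the cyclopentyl ring matters, or whether a hydroxyl there would serve equally. Also open, as far as these compounds go, are the part played by the defined stereocentres and whether an open chain such as (2-aminoethyl)amino could replace the ring.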